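This account rests on a few compounds, and the source may have more. Where it says the series, first, only, none or still open, it means among the compounds named here.

Measured in a functional assay on MDA-MB-468 cells (Homo sapiens) for antiproliferative activity; a lower number here means a stronger inhibitor, a higher number a weaker inhibitor:
- compound 1 `Cc1cc(-c2nc3ccccc3s2)ccc1N`: < 1 nM (a limit)
- compound 2 `CC(=O)Nc1ccc(-c2nc3ccccc3s2)cc1C`: > 10000 nM (a limit)

Compound 2 is known only as a limit, > 10000 nM, at the weak end of the two values. Compound 3 `CC(=O)Nc1ccc(-c2nc3ccccc3s2)cc1Br` keeps the acetyl and changes one substituent: bromo in place of methyl on an aromatic carbon, bromo in place of methyl, ortho to an acetamido group. Going by the values given here, the only measured step, an at least 10000-fold higher number from compound 1 to compound 2 (4.00 log units; beyond the scatter), is large, but it concerns the acetyl on nitrogen and does not test this swap. In this assay the expected step is a step that the limit leaves unreadable from compound 2 to compound 3, with none expected beyond the scatter. For compound 3 the estimate is 15000 nM, within an expected range of 4000 nM to 40000 nM, and a report as a limit is likely.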

Compound 3, half-maximal inhibitory concentration: > 100 nM
Compound 3: a limit, no number (the forecaster's own chance of this, stated with the estimate: 80%); the middle value lies beyond the limit too.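

Going by these compounds alone, compound 2 and compound 3 stand only as limits in this assay, and no step between them can be read. The compounds shown leave open whether bromo in place of methyl on an aromatic carbon changes the number at all.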